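This account rests on a few compounds, and the source may have more. Where it says the series, first, only, none or still open, it means among the compounds named here.

In a functional assay on HeLa cells (Homo sapiens) for inhibition (a higher number here means a weaker inhibitor, a lower number a stronger inhibitor), compound 1 `CC(C)(C)c1ccc(C(=O)CC(SCC(=O)O)C(=O)O)cc1` gives 1390 nM, compound 2 `O=C(O)CSC(CC(=O)c1ccc(F)cc1)C(=O)O` gives 20700 nM, and compound 3 `O=C(O)CSC(CC(=O)c1ccc(Cl)cc1)C(=O)O` gives 17200 nM. Compound 3 thus stands second highest of the three numbers: the gap to compound 2 is within the scatter, while a 12-fold higher number from compound 1 to compound 3 (1.09 log units; beyond the scatter). Compound 4 `O=C(O)CSC(CC(=O)c1ccc(Br)cc1)C(=O)O` carries bromo in place of chloro on an aromatic carbon. For the measured compounds named here, the only measured step that bears on this is the exchange of one halogen for another, a 1.2-fold lower number from compound 2 to compound 3 (0.08 log units; within the scatter); the large step of a 15-fold higher number from compound 1 to compound 2 (1.17 log units; beyond the scatter) and the equally large step from the tert-butyl compound to compound 3 both concern the tert-butyl and do not bear on it. For compound 4 in this assay a step of a 1.1-fold lower number from compound 3 to compound 4 (0.06 log units; within the scatter) is therefore expected, none beyond the scatter. Compound 4 is estimated at 15000 nM, within 7000 nM to 35000 nM.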

Compound 4, half-maximal inhibitory concentration: 9500 nM
The estimate for compound 4 lay 1.6-fold (0.20 log units) above the measured number; measured number inside the range.
By their numbers in this assay, from the lowest: compound 1; then compounds 4, 3 and 2 (each within the scatter of the next, the first and the last beyond it).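

In this assay, the halogens at this position, para to a large group, now separate: a 2.2-fold lower number from compound 2 to compound 4 (0.34 log units; beyond the scatter) lies beyond the scatter, whereas a 1.8-fold lower number from compound 3 to compound 4 (0.26 log units; within the scatter) stays within it. Bromo does not match tert-butyl, with a 6.8-fold higher number from compound 1 to compound 4 (0.83 log units; beyond the scatter) also beyond the scatter. No measured evidence bears on the cause of these differences.

Open, going by these compounds, is whether iodo, methyl or methoxy at this position would fall with the halogens or with tert-butyl. Also open, on these data alone, is how an ester or an amide in place of either carboxylic acid would behave.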